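This account rests on a few compounds, and the source may have more. Where it says the series, first, only, none or still open, it means among the compounds named here.

Working notes on a small alkyne-linked series tested in an assay on HEK293 cells for positive allosteric modulation of metabotropic glutamate receptor 5 (Rattus norvegicus); a lower number here means that less compound is needed, a higher number that more compound is needed for the effect. Compound 1 `COc1ncc(C#Cc2ccc(C)cc2)cn1` gives "not active" (no number reported) in this assay. Among the compounds with values here, compound 2 `CNc1ncc(C#Cc2ccc(C)cc2)cn1` is the only member with a number in this assay, where compound 2 gives 704000 nM. Compound 3 `Cc1ccc(C#Cc2cnc(C(C)(C)C)nc2)cc1` gives "not active" (no number reported) in this assay, so it stands without a single number, as compound 1 does. Compound 4 `CCNc1ncc(C#Cc2ccc(C)cc2)cn1` has not been measured. It differs from compound 3 by ethylamino in place of tert-butyl on an aromatic carbon. Within the data shown here, no measured step covers this change; the nearest reference is compound 2, which gives 704000 nM. Compound 4 is expected to come out near that weak level rather than remaining without a number, though a result without a number stays plausible. Compound 4 is estimated at 500000 nM in this assay, within 100000 nM to 2000000 nM.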

Compound 4, half-maximal effective concentration: "not active" (no number reported)
The entry for compound 4 holds no number, and the estimate cannot be compared.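

Compound 3 and compound 4 both stand without a number in this assay, so no step can be read between them. The compounds shown leave open how tert-butyl and ethylamino compare in this assay. No supporting data bear on this result.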